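Working notes: from 4-methoxyphenyl to 4-chlorophenyl

A few compounds are considered here, and "the series" means these few. Any claim that something is new, unique, unknown or untested is made for them only; others in the source may bear on it.

Measured so far in a functional assay on MCF7 cells (Homo sapiens) for antiproliferative activity, read by MTT assay, with a stated time of 72 h (on this read-out lower numbers stand for stronger inhibition and higher numbers for weaker inhibition), for the series:
- compound 1 `COc1ncc(-c2ccc3c(c2)N(c2ccc(F)cc2)C(=O)CO3)cc1NS(=O)(=O)c1ccc(F)cc1` gives > 40000 nM as a limit
- compound 2 `COc1ncc(-c2ccc3c(c2)N(c2ccccc2)C(=O)CO3)cc1NS(=O)(=O)c1ccc(F)cc1` gives 8870 nM as a number
- compound 3 `COc1ccc(N2C(=O)COc3ccc(-c4cnc(OC)c(NS(=O)(=O)c5ccc(F)cc5)c4)cc32)cc1` gives 8260 nM as a number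

Compound 3 at 8260 nM sits within the scatter of compound 2 at 8870 nM on the two numbers available. Compound 4 `COc1ncc(-c2ccc3c(c2)N(c2ccc(Cl)cc2)C(=O)CO3)cc1NS(=O)(=O)c1ccc(F)cc1` has chloro in place of methoxy on an aromatic carbon, para to a large group (chloro in place of methoxy on an aromatic carbon). For the measured compounds named here, three steps bear on this. Both an at least 4.8-fold lower number from compound 1 to compound 3 (0.68 log units; beyond the scatter) and an at least 4.5-fold lower number from compound 1 to compound 2 (0.65 log units; beyond the scatter) lie beyond the scatter and start from a limit, while a 1.1-fold lower number from compound 2 to compound 3 (0.03 log units; within the scatter) lies within it. Fluoro is the only halogen measured here, so a modest rise is expected, though its size is uncertain: a 1.9-fold higher number from compound 3 to compound 4 (0.29 log units; within the scatter) in this assay is the expected step. Compound 4 is estimated at 16000 nM with 6000 nM to 40000 nM as its expected range.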

Compound 4, half-maximal inhibitory concentration: 27600 nM
The estimate for compound 4 lay 1.7-fold (0.24 log units) below the measured number; measured number inside the range.
By their numbers in this assay, from the lowest: compounds 3 and 2 (each within the scatter of the next); then compound 4. At a limit, above all of these: compound 1.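

In this assay a second halogen at this position now gives a number well clear of those of the non-halogen compounds (a 3.1-fold higher number from compound 2 to compound 4 (0.49 log units; beyond the scatter); a 3.3-fold higher number from compound 3 to compound 4 (0.52 log units; beyond the scatter)), whereas hydrogen and methoxy did not separate. Chloro and fluoro cannot yet be ordered (an at least 1.4-fold lower number from compound 1 to compound 4 (0.16 log units; that floor lies within the scatter)), with that floor lying within the scatter. Compound 1 remains a limit, not a number: the limit of > 40000 nM in this assay, at which 1 of the 4 values shown sits.

Still open, going by these compounds, is whether the halogen trend extends to bromo or trifluoromethyl. On these data alone, how an amine or a carboxylic acid would read at this position also remains open.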